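Swapping a Fluorinated Ester for a Phenylglycine Arm

The source may report more compounds than this note shows. Statements on the series, on what has been measured and on what is new or still open speak of the compounds shown alone.

Compound 2 `COC(=O)C(F)(F)Nc1cc(CS(=O)(=O)/C=C/c2c(OC)cc(OC)cc2OC)ccc1OC` is, on the numbers in hand, the weaker of two measured compounds: in a functional assay on K562 cells (Homo sapiens) for cytotoxicity, read by trypan blue exclusion, with a stated time of 96 h (a lower number here means a stronger inhibitor, a higher number a weaker inhibitor), compound 2 gives 250 nM, whereas compound 1 `COc1ccc(CS(=O)(=O)/C=C/c2c(OC)cccc2OC)cc1N` gives 50 nM, a gap that lies beyond the usual scatter. Compound 3 `COc1cc(OC)c(/C=C/S(=O)(=O)Cc2ccc(OC)c(NC(C(=O)O)c3ccccc3)c2)c(OC)c1` has not yet been measured. It differs from compound 2 in one place: carboxy(phenyl)methyl in place of difluoro(methoxycarbonyl)methyl on a nitrogen on an aromatic ring. Going by the values given here, no measured pair shows this exact change, so the data give no step to lean on. Among the compounds with values here, with only a single value for compound 2 to go from, and no guide to the direction, the change from compound 2 to compound 3 is expected to produce a step of a 1.3-fold lower number from compound 2 to compound 3 (0.10 log units; within the scatter), that is, nothing clearly beyond the scatter in either direction. Compound 3 is therefore estimated at 200 nM, within a range from 50 nM to 800 nM.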

Compound 3, half-maximal inhibitory concentration: 15 nM
The estimate for compound 3 lay 13-fold (1.12 log units) above the measured number, outside the stated range (below it).
By their numbers in this assay, from the lowest: compound 3; then compound 1; then compound 2.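

In this assay, the change on the nitrogen on an aromatic ring gives a 17-fold lower number from compound 2 to compound 3 (1.22 log units; beyond the scatter), so the group carried at this place can strongly alter the cytotoxicity read-out. This single change also shows that an arm with a six-membered aromatic ring and a hydrogen-bond donor is compatible with a much lower number than the difluoro(methoxycarbonyl)methyl arm gives. Nothing measured here explains the size of this step.

The swap removes both fluorines and the methyl ester and adds a phenyl ring and a free carboxylic acid at once, so the compounds shown cannot say which of these parts accounts for the step. Carboxymethyl, which has no phenyl ring, and methoxycarbonyl(phenyl)methyl, which has no free acid, would be the groups that could separate those contributions.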